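Dropping a methyl from the core of compound 1

A few compounds are considered here, and "the series" means these few. Any claim that something is new, unique, unknown or untested is made for them only; others in the source may bear on it.

Measured so far:
- compound 1, `Cc1cnc2nc(-c3ccc4ccccc4c3)cc(O)c2c1`: 132 nM
- compound 2, `Cc1cc(C)c2c(O)cc(-c3ccc4ccccc4c3)nc2n1`: 3240 nM
- compound 3, `Cc1ccnc2nc(-c3cccc(Cl)c3)cc(O)c12`: 11.8 nM

Of the compounds shown here, three sharing one core have been tested in a functional assay on MDA-N cells (Homo sapiens) for antiproliferative activity; a higher number here means a weaker inhibitor of growth, a lower number a stronger inhibitor of growth. Compound 1 gives 132 nM, the second highest of the three numbers. Compound 3 sits well below it, a gap beyond the usual scatter, and compound 2 sits well above it, also beyond the scatter. No pair of these compounds differs in a single place, so no step can be read off directly.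

Compound 4, `Oc1cc(-c2ccc3ccccc3c2)nc2ncccc12`, has not been measured. It is compound 1 with one change: hydrogen in place of methyl on an aromatic carbon. The two-methyl compound 2 and the differently substituted compound 3 do not isolate this methyl, so the data give no guide to its weight. A methyl is a small group, and the change is expected to be modest, a step from compound 1 to compound 4 of about a 1.9-fold higher number from compound 1 to compound 4 (0.28 log units; within the scatter), leaning toward slightly weaker growth inhibition. Compound 4 is therefore estimated at 250 nM, with a range from 60 nM to 1000 nM.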

Compound 4, concentration for 50% growth inhibition: 1660 nM
For compound 4 the middle estimate is 6.6-fold (0.82 log units) below the measured one; measured number above the stated range.
By their numbers in this assay, from the lowest: compound 3; then compound 1; then compounds 4 and 2 (each within the scatter of the next).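

In this assay, putting hydrogen in place of the methyl gives a 13-fold higher number from compound 1 to compound 4 (1.10 log units; beyond the scatter), so this aromatic carbon is far from indifferent to what it carries. Within the data shown here, this is the first reading of that methyl on its own: the change removes a single heavy atom and involves no ring, no net charge and no hydrogen-bond donor or acceptor, yet the step lies beyond the scatter. Nothing at hand explains why so small a change counts for so much.

As far as these compounds go, it remains open whether methyl is special here: an ethyl chain, a methoxy group or an amine on the same carbon would show whether other groups match or improve on compound 1. From the compounds shown here alone, it is also open whether a methyl at this place would carry the same weight in a compound built like compound 3.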